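A few compounds are considered here, and "the series" means these few. Any claim that something is new, unique, unknown or untested is made for them only; others in the source may bear on it.

compound 1 `CCOC(=O)c1cc(-c2cccc(OCc3cccc(N)c3)c2)on1`: > 128000 nM
compound 2 `CCOC(=O)c1cc(-c2cccc(OCc3ccc(C(F)(F)F)cc3)c2)on1`: > 128000 nM
compound 3 `CCOC(=O)c1cc(-c2cccc(OCc3cccc(C(F)(F)F)c3F)c2)on1`: > 128000 nM

All three were tested in an ADME assay on Vero cells (Chlorocebus sabaeus) for cytotoxicity, with a stated time of 72 h; on this read-out higher numbers stand for weaker inhibition and lower numbers for stronger inhibition. For compound 1 the value > 128000 nM is a limit of the assay, not a measured number. For compound 2 the value > 128000 nM is likewise a limit. For compound 3 the value > 128000 nM is also a limit. Among the measured compounds shown here, compound 1 therefore stands exactly where the others stand, at the limit of > 128000 nM in this assay, at which 3 of the 3 values shown sit, and no compound in this set gives a number within the measurable range.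

Compound 4 `CCOC(=O)c1cc(-c2cccc(OCc3c(F)cccc3F)c2)on1` has not yet been measured. It differs from compound 1 in one place: 2,6-difluorophenyl in place of 3-aminophenyl on a saturated chain carbon bound to an oxygen on an aromatic ring. For the measured compounds named here, no step between two measured compounds is available, so the size of this change cannot be read from an earlier pair. The expectation for compound 4 in this assay is a step of no size beyond the scatter, a step that the limit leaves unreadable from compound 1 to compound 4, because every measured value sits at the limit of > 128000 nM in this assay, at which 3 of the 3 values shown sit. Compound 4 is expected to give 150000 nM, estimated to lie between 64000 nM and 350000 nM, and most likely to be reported once more as a limit.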

Compound 4, half-maximal inhibitory concentration: > 128000 nM
Compound 4: no number, only a limit; the forecaster's own chance of this, stated with the estimate: 85%; the middle value lies beyond the limit too.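

No step can be read from compound 1 to compound 4, since both results are limits of the assay and not numbers: the limit of > 128000 nM in this assay, at which 4 of the 4 values shown sit.

The compounds shown leave open what concentration, if any, would give half-maximal inhibition in this assay, and whether swapping 3-aminophenyl for 2,6-difluorophenyl changes it.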